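A few compounds are considered here, and "the series" means these few. Any claim that something is new, unique, unknown or untested is made for them only; others in the source may bear on it.

Among the compounds with values here, compound 1, `CC(C)=CCCC1=CC[C@@H](C(=O)Nc2ccc(C(=O)O)cc2)[C@H](c2ccccc2)C1`, is the first of the pair whose numbers are known. In an assay on isolated protein for inhibition of Apoptosis regulator Bcl-2 (Homo sapiens), read by fluorescence polarization, with stated times of 5 min and 10 min (on this read-out higher numbers stand for weaker inhibition and lower numbers for stronger inhibition), compound 1 gives 2200 nM. Compound 2, `CC(C)=CCCC1=CC[C@@H](C(=O)Nc2ccc(O)cc2)[C@H](c2ccccc2)C1`, keeps the shared core and differs only in the group on the far aromatic carbon. In this assay compound 2 gives > 23000 nM, which is a limit of the assay rather than a number, as the limit of > 23000 nM in this assay, at which 1 of the 2 values shown sits, records. Within the data shown here, the one measured step, an at least 10-fold higher number from compound 1 to compound 2 (1.01 log units; beyond the scatter), is large and lies beyond the scatter, so compound 2 stands at the weak end of what has been seen. Compound 3, `CC(C)=CCCC1=CC[C@@H](C(=O)N(C)O)[C@H](c2ccccc2)C1`, takes a further step from compound 2: hydroxy(methyl)amino in place of (4-hydroxyphenyl)amino on a carbonyl carbon. Among the measured compounds shown here, no measured step touches this part of the molecule, so the only guide is that compound 2 already sits at the limit. The step that the limit leaves unreadable from compound 2 to compound 3 is therefore expected to stay near zero. Compound 3 is estimated at 30000 nM, in the range 10000 nM to 100000 nM.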

Compound 3, inhibition constant: 2300 nM
Estimate against measurement, compound 3: 13-fold (1.12 log units) above; the measured number lies below the stated range.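

On the carbonyl carbon, the aromatic amine part can give way to a small group with no ring without losing binding: in this assay there is an at least 10-fold lower number from compound 2 to compound 3 (1.00 log units; beyond the scatter) when hydroxy(methyl)amino replaces (4-hydroxyphenyl)amino, and there is a 1.0-fold higher number from compound 1 to compound 3 (0.02 log units; within the scatter) when it replaces (4-carboxyphenyl)amino. The aromatic ring is therefore not needed here to reach the level of compound 1, and compound 2 shows that having the ring does not secure that level either. Compound 2 carries a limit of the assay and not a number, so the exact size of its step cannot be read: the limit of > 23000 nM in this assay, at which 1 of the 3 values shown sits.

Still open, from the compounds shown here alone, is which part of hydroxy(methyl)amino matters, the hydroxy or the methyl. A plain methylamino group or a methoxy(methyl)amino group on the same carbonyl carbon would separate the two.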